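Removing the para-chloro: what compound 4 might give

The source may hold more compounds than are shown below. What is called first, only, known or untested is meant among the compounds shown, and "the series" means these compounds.

Of the compounds shown here, three built on a shared core have been measured in a functional assay on MCF7 cells (Homo sapiens) for cytotoxicity, read by MTT assay, with a stated time of 48 h; on this read-out lower numbers stand for stronger inhibition and higher numbers for weaker inhibition. Compound 1 `COc1ccc(/C=C2\N=C(c3ccc(C)cc3)N(C(=O)c3nc4c(c(C)nn4-c4ccccc4)c(=O)[nH]3)NC2=O)cc1` gives 17.3 nM, compound 2 `Cc1nn(-c2ccccc2)c2nc(C(=O)N3NC(=O)/C(=C/c4ccccc4)N=C3c3ccccc3)[nH]c(=O)c12` gives 120 nM, and compound 3 `COc1ccc(/C=C2\N=C(c3ccc(Cl)cc3)N(C(=O)c3nc4c(c(C)nn4-c4ccccc4)c(=O)[nH]3)NC2=O)cc1` gives 32.9 nM. Compound 3 thus stands second highest of the three numbers; its nearest neighbour is compound 1, whose number is lower by an amount within the scatter, while compound 2 lies furthest, with a number higher beyond the scatter.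

Among the compounds with values here, the one measured step that differs in a single place, a 1.9-fold higher number from compound 1 to compound 3 (0.28 log units; within the scatter), changes only methyl to chloro on an aromatic carbon and stays within the scatter. Compound 4 `COc1ccc(/C=C2\N=C(c3ccccc3)N(C(=O)c3nc4c(c(C)nn4-c4ccccc4)c(=O)[nH]3)NC2=O)cc1` takes the next step from compound 3: hydrogen in place of chloro on an aromatic carbon, on a six-membered aromatic ring of carbon only, para to a large group. Within the data shown here, no measured pair shows exactly this exchange; compound 2 also carries a plain phenyl at that position, but it differs from compound 4 in more than one place, so its value only hints that an unsubstituted ring can pair with a higher number.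

Given the small step between compound 1 and compound 3 and the unclear weight of compound 2, a modest rise, a 1.4-fold higher number from compound 3 to compound 4 (0.14 log units; within the scatter), is expected in this assay. Compound 4 is therefore estimated at 45 nM, with a likely range from 15 nM to 140 nM.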

Compound 4, half-maximal inhibitory concentration: 61.3 nM
The estimate for compound 4 lay 1.4-fold (0.13 log units) below the measured number, and the stated range covers the measured number.
By their numbers in this assay, from the lowest: compounds 1, 3, 4 and 2 (each within the scatter of the next, the first and the last beyond it).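

In this assay, the change from 4-chlorophenyl to phenyl now has its own reading (a 1.9-fold higher number from compound 3 to compound 4 (0.27 log units; within the scatter)), which shows that removing the chloro alone does not carry the number past the scatter. Hydrogen in place of methyl at this same aromatic carbon does go beyond the scatter (a 3.5-fold higher number from compound 1 to compound 4 (0.55 log units; beyond the scatter)), a modest separation that the chloro compound does not resolve, since compound 3 lies within the scatter of both compound 1 and compound 4. The methoxy exchange on the other aromatic ring also stays within the scatter (a 2.0-fold lower number from compound 2 to compound 4 (0.29 log units; within the scatter)), so with a plain phenyl at the position discussed here, the presence of methoxy gives no clear separation.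

The data shown offer no measurement that accounts for the separation between the methyl and hydrogen compounds. Also open, as far as these compounds go, is how an amine, a carboxylic acid or a longer chain such as ethyl at this carbon would read against methyl and hydrogen, and whether the gap between those two holds when the methoxy is absent.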